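This account rests on a few compounds, and the source may have more. Where it says the series, first, only, none or still open, it means among the compounds named here.

Measured so far in an assay on CHO cells for displacement of a labelled ligand from adenosine receptor A1 (Homo sapiens), read by scintillation counting, with a stated time of 60 min, tested at 10 uM; a lower number here means less inhibition, a higher number more inhibition at the concentration tested (going by the name of the read-out):
- compound 1, `CNC(=O)[C@@]12C[C@@H]1[C@@H](n1cnc3c(NC)nc(C#Cc4cccc(F)c4)nc31)[C@H](O)[C@@H]2O`: 14%
- compound 2, `CNC(=O)[C@@]12C[C@@H]1[C@@H](n1cnc3c(NC)nc(C#Cc4ccc(Cl)cc4)nc31)[C@H](O)[C@@H]2O`: 13%

Compound 2 holds the lower of the two numbers in this assay, but its gap to compound 1 is within the scatter, so the two compounds cannot be ordered on what is shown. Going by the values given here, the one measured step, a number 1 percentage points lower from compound 1 to compound 2 (within the scatter), exchanged the group on the triple-bonded carbon and produced no change beyond the scatter.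

Compound 3, `CNC(=O)[C@@]12C[C@@H]1[C@@H](n1cnc3c(NC)nc(C#Cc4ccccc4OC)nc31)[C@H](O)[C@@H]2O`, has not been measured. It differs from compound 2 as follows: 2-methoxyphenyl in place of 4-chlorophenyl on a triple-bonded carbon. The step from compound 1 to compound 2 bears on it, since it also replaced the aromatic ring on the triple-bonded carbon, and it was small. No measured compound carries a 2-methoxyphenyl group, so the effect of the hydrogen-bond acceptor that enters is not covered by any step shown.

On this basis the expected step in this assay, no change at the digits printed from compound 2 to compound 3 (within the scatter), is none beyond the scatter. Going by these compounds, compound 3 is estimated at 13%, with a range from 2% to 30%, the range widened because the entering group is untested here.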

Compound 3, a percentage reported as inhibition, at one concentration (the size of the read-out at that concentration, not a potency): 12%
Compound 3: the middle estimate sits 1 percentage points above what was measured, within the range that was stated.
By their numbers in this assay, from the lowest: compounds 3, 2 and 1 (each within the scatter of the next).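

Each step in this assay that brings in 2-methoxyphenyl on the triple-bonded carbon stays within the scatter: a number 1 percentage points lower from compound 2 to compound 3 (within the scatter) against the 4-chlorophenyl group and a number 2 percentage points lower from compound 1 to compound 3 (within the scatter) against the 3-fluorophenyl group. The earlier step exchanged one halogen-bearing phenyl group for another, whereas these two steps show that a group with a hydrogen-bond acceptor, carrying oxygen in place of halogen, also leaves the read-out unchanged within the scatter at this position. The three compounds therefore cannot be ordered, and no evidence on the compounds accounts for this result.

The compounds shown leave open whether a charged or hydrogen-bond-donating substituent on the phenyl ring, such as an aminomethyl group or a carboxylic acid, would separate from these values, and whether replacing the phenyl ring with a saturated ring such as cyclohexyl or with a longer alkyl chain would do so. They also leave open how these compounds compare in potency, since the read-out is a single-concentration inhibition value and gives no concentration-response measure for any of the three.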